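Swapping the aryl amine on a shared core

This account rests on a few compounds, and the source may have more. Where it says the series, first, only, none or still open, it means among the compounds named here.

Compound 3 `Cc1cc(=O)oc2cc(OCc3nc(N)nc(Nc4ccc(Cl)c(Cl)c4)n3)ccc12` gives 780 nM in an assay on COS-7 cells for agonist activity at Free fatty acid receptor 1 (Homo sapiens), read by scintillation counting and inositol phosphate accumulation, with a stated time of 90 min (on this read-out higher numbers stand for an effect only at larger amounts of compound and lower numbers for an effect already at smaller amounts), the second highest of the three measured numbers. Compound 2 `Cc1cc(=O)oc2cc(OCc3nc(N)nc(Nc4ccc(C(C)C)cc4)n3)ccc12` gives 460 nM in this assay, and compound 1 `Cc1cc(=O)oc2cc(OCc3nc(N)nc(Nc4ccc(F)cc4)n3)ccc12` gives 18300 nM. Compound 4 `Cc1cc(=O)oc2cc(OCc3nc(N)nc(NCc4ccc(F)cc4)n3)ccc12` differs from compound 3 by 4-fluorobenzyl in place of 3,4-dichlorophenyl on a nitrogen on an aromatic ring. The step that bears most on this is a 23-fold lower number from compound 1 to compound 3 (1.37 log units; beyond the scatter), since the entering 4-fluorobenzyl carries the same fluorine as the 4-fluorophenyl of compound 1, though attached as a benzyl rather than a phenyl. Also relevant is a 40-fold lower number from compound 1 to compound 2 (1.60 log units; beyond the scatter), which shows the fluorinated group gave the highest number. A return toward compound 1 is therefore expected, a step of a 10-fold higher number from compound 3 to compound 4 (1.01 log units; beyond the scatter), with the untested benzyl attachment widening the range. Compound 4 is expected at 8000 nM, between 2000 nM and 30000 nM.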

Compound 4, half-maximal effective concentration: 7820 nM
Beside the measured number, compound 4's estimate is 1.0-fold (0.01 log units) above it, and the stated range covers the measured number.
By their numbers in this assay, from the lowest: compounds 2 and 3 (each within the scatter of the next); then compound 4; then compound 1.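

Holding the fluorinated ring as a benzyl rather than a phenyl on this nitrogen gives only a 2.3-fold lower number from compound 1 to compound 4 (0.37 log units; beyond the scatter), while the 4-fluorobenzyl remains well short of the two chlorinated and isopropyl-bearing groups, with a 10-fold higher number from compound 3 to compound 4 (1.00 log units; beyond the scatter) and a 17-fold higher number from compound 2 to compound 4 (1.23 log units; beyond the scatter). Among these four compounds, both fluorine-bearing groups, whether attached as phenyl or benzyl, give higher numbers than 3,4-dichlorophenyl and 4-isopropylphenyl. Nothing available here explains these differences. Still open, going by these compounds, is whether a 3,4-dichlorobenzyl or 4-isopropylbenzyl would track its phenyl counterpart, and how a longer chain on this nitrogen would read.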